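The compounds below may be only part of what the source reports. "The series", "measured", "known", "first", "only" and "open" are said of these compounds alone.

Measured in an ADME assay on Vero cells (Chlorocebus sabaeus) for cytotoxicity; a lower number here means that less compound is tolerated, a higher number that more compound is tolerated:
compound 1 `CC(=O)c1c(Nc2ccc(F)cc2F)[nH]c2c(C(F)(F)F)cc(Cl)cc2c1=O` gives 7300 nM
compound 2 `CC(=O)c1c(Nc2ccc(F)cc2F)[nH]c2c(F)cc(Cl)cc2c1=O` gives > 25000 nM, which is a limit
compound 3 `CC(=O)c1c(Nc2ccc(F)cc2F)[nH]c2c([N+](=O)[O-])cc(Cl)cc2c1=O` gives > 25000 nM, which is a limit

Compound 2 stands at the limit of > 25000 nM in this assay, at which 2 of the 3 values shown sit, and so carries no number. Compound 4 `CC(=O)c1c(Nc2ccc(F)cc2F)[nH]c2c(F)cc(F)cc2c1=O` differs from it in one place: fluoro in place of chloro on an aromatic carbon. The two readable steps, an at least 3.4-fold higher number from compound 1 to compound 2 (0.53 log units; beyond the scatter) and an at least 3.4-fold higher number from compound 1 to compound 3 (0.53 log units; beyond the scatter), each replace trifluoromethyl and leave chloro untouched, so they give no size for this swap. No step beyond the scatter is therefore expected in this assay, and a result reported only as a limit is likely. Compound 4 is estimated at 28000 nM, with an expected range from 14000 nM to 50000 nM. The expected step is a step that the limit leaves unreadable from compound 2 to compound 4.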

Compound 4, half-maximal cytotoxic concentration: > 25000 nM
Compound 4: a limit, no number; the forecaster's own chance of this, stated with the estimate: 75%; the middle value lies beyond the limit too.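

In this assay, among these compounds, compound 2 and compound 4 both stand at a limit, so no step between them can be read: the limit of > 25000 nM in this assay, at which 3 of the 4 values shown sit. The compounds shown leave open how much fluoro in place of chloro changes the tolerated concentration.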